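The source may hold more compounds than are shown below. What is called first, only, known or untested is meant among the compounds shown, and "the series" means these compounds.

In a functional assay on NCI-H460 cells (Homo sapiens) for inhibition, read by sulforhodamine B assay, with a stated time of 48 h (on this read-out higher numbers stand for weaker inhibition of growth and lower numbers for stronger inhibition of growth), compound 1 `CC(C)(C)NCc1c(C(=O)O)nn(-c2ccccc2)c1-c1ccc(Cl)cc1` gives 70500 nM. Compound 2 `CC(C)(C)NCc1c(C(=O)O)nn(-c2ccccc2)c1-c1ccc(Br)cc1`, which carries bromo in place of chloro on an aromatic carbon, gives > 585000 nM in this assay, and this figure is a limit of the assay, not a number. Compound 2 therefore has no exact place on the scale, and only its limit is known. Compound 3 `CC(C)(C)NCc1c(C(=O)O)nn(-c2ccccc2)c1-c1ccccc1` takes the next step at that same aromatic carbon, with hydrogen in place of bromo on an aromatic carbon. The 4-bromophenyl becomes phenyl. Among the measured compounds shown here, only one measured step bears on this change, an at least 8.2-fold higher number from compound 1 to compound 2 (0.91 log units; beyond the scatter), which lies beyond the scatter and involves the same carbon. For the measured compounds named here, no measured compound yet has hydrogen there, so the expectation rests on that single step and stays loose. Going by the step to compound 2 in an at least 8.2-fold higher number from compound 1 to compound 2 (0.91 log units; beyond the scatter), losing bromo is expected to lower the number, possibly towards the level of compound 1 at 70500 nM. The expected change is an at least 4.8-fold lower number from compound 2 to compound 3 (0.68 log units; beyond the scatter). Compound 3 is estimated at 120000 nM, with an expected range from 30000 nM to 585000 nM.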

Compound 3, concentration for 50% growth inhibition: > 716000 nM
Compound 3 gave a limit, no number; the forecaster's own chance of this, stated with the estimate: 25%; middle value at least 5.9-fold (0.77 log units) from the limit.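

Hydrogen in place of chloro on this aromatic carbon gives an at least 10-fold higher number from compound 1 to compound 3 (1.00 log units; beyond the scatter), so the loss of the halogen does not leave growth inhibition at the level of compound 1; the phenyl compound falls on the weak side, as the 4-bromophenyl compound does. In this assay, chloro is thus the only one of the three substituents at this carbon that yields a measured number, and the step with bromo no longer stands alone as evidence that compound 1 is set apart, although the step between the two compounds that carry limits cannot be read. The value of compound 3 is a limit of the assay and not a number: the limit of > 716000 nM in this assay, at which 1 of the 3 values shown sits.

From the compounds shown here alone, how compound 2 and compound 3 rank against each other stays unknown, and so does how far either lies from compound 1 beyond what the limits show. Also open, going by these compounds, is whether fluoro, methyl or methoxy on this aromatic carbon would give a number near that of compound 1, and whether the chloro result would hold if the carboxylic acid gave way to an ester or an amide.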